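The source may hold more compounds than are shown below. What is called first, only, known or untested is meant among the compounds shown, and "the series" means these compounds.

Measured compounds:
compound 1 `Cc1ccc2c(C3CCN(CCN4CCN(C(C)C)C4=O)CC3)cn(-c3ccc(F)cc3)c2c1` gives 85 nM
compound 2 `CN(C)C(=O)NCCN1CCC(c2cn(-c3ccc(F)cc3)c3cc(Cl)ccc23)CC1` gives 29 nM

Two compounds carry a number in an assay on cell membranes for displacement of a labelled ligand from Adrenergic receptor alpha-1 (Rattus norvegicus); on this read-out higher numbers stand for weaker inhibition and lower numbers for stronger inhibition. Compound 2 stands at the lower of the two values with 29 nM; compound 1, with its cyclic urea carrying an isopropyl group and a methyl on the fused ring, gives a higher number, and the gap between the two lies beyond the usual scatter. Among the measured compounds shown here, the two compounds differ in more than one place, so no single step is drawn between them.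

Compound 3 `Cc1ccc2c(C3CCN(CCNC(=O)N(C)C)CC3)cn(-c3ccc(F)cc3)c2c1` has not been measured in this assay. It keeps the dimethylurea side chain of compound 2 and differs from it in one place: methyl in place of chloro on an aromatic carbon. For the measured compounds named here, no step of this kind between measured compounds is available, so the size of the effect is open. Swapping one heavy atom for another of the same count, with no change in hydrogen-bond donors, acceptors or charge, is expected to move the number only modestly, if at all, with the direction uncertain and a slight weakening considered somewhat more likely.

For compound 3 the expected value in this assay is 40 nM, with a range of 15 nM to 110 nM. The step from compound 2 to compound 3 is thus expected to be a 1.4-fold higher number from compound 2 to compound 3 (0.14 log units; within the scatter).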

Compound 3, half-maximal inhibitory concentration: 22 nM
Compound 3: the middle estimate sits 1.8-fold (0.26 log units) above what was measured, and the stated range covers the measured number.
By their numbers in this assay, from the lowest: compounds 3 and 2 (each within the scatter of the next); then compound 1.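

In this assay the aromatic carbon meta to a fused ring and para to a fused ring accepts methyl in place of chloro with no readable change, as a 1.3-fold lower number from compound 2 to compound 3 (0.12 log units; within the scatter) stays within the scatter and the two groups cannot be told apart here. With the methyl kept on the core, replacing 3-isopropyl-2-oxoimidazolidin-1-yl with (dimethylcarbamoyl)amino on the saturated chain gives a 3.9-fold lower number from compound 1 to compound 3 (0.59 log units; beyond the scatter) and thus moves the number beyond the scatter, which makes the side chain the only place among these compounds where a single change has a clear effect. No accompanying measurement bears on what lies behind either step.

From the compounds shown here alone, what a methoxy or a nitrile would do on the aromatic carbon stays open, and two groups give no trend for this position. Also open, going by these compounds, are the effect of an amide or a longer chain in place of the urea side chain, and whether methyl and chloro would remain indistinguishable when paired with the cyclic urea carrying the isopropyl group.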